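Methyl to Hydrogen on a Weakly Active Chromone Series

This account rests on a few compounds, and the source may have more. Where it says the series, first, only, none or still open, it means among the compounds named here.

Four closely related compounds share a fused core and have been examined in a functional assay on MDA-MB-231 cells (Homo sapiens) for antiproliferative activity, read by MTT assay; a lower number here means a stronger inhibitor, a higher number a weaker inhibitor. Compound 1 `Cc1oc2c3c(ccc2c(=O)c1C)OC[C@H]1[C@@H]3Nc2ccccc2C1(C)C` reaches only the limit of the assay, > 100000 nM. Compound 2 `Cc1oc2c3c(ccc2c(=O)c1C)OC[C@H]1[C@@H]3Nc2cc3ccccc3cc2C1(C)C` likewise gives only a limit in this assay, > 100000 nM. For the measured compounds named here, compound 3 `Cc1coc2c3c(ccc2c1=O)OC[C@H]1[C@@H]3Nc2ccccc2C1(C)C` is the one member with a number, 93800 nM. Going by the values given here, the single comparable step, an at least 1.0-fold lower number from compound 1 to compound 3 (0.02 log units; that floor lies within the scatter), lies within the scatter, and both compound 1 and compound 2 sit at the limit noted in the limit of > 100000 nM in this assay, at which 2 of the 3 values shown sit.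

Compound 4 `Cc1coc2c3c(ccc2c1=O)OC[C@H]1[C@@H]3Nc2cc3ccccc3cc2C1(C)C` is compound 2 with one change: hydrogen in place of methyl on an aromatic carbon. The matching change from compound 1 to compound 3 moved the number no further than the scatter, so for compound 4 no step beyond the scatter is expected in either direction in this assay; the step of a number no higher from compound 2 to compound 4 (the limit leaves the size open) is expected to be essentially flat. Compound 4 is therefore estimated at 100000 nM, within 50000 nM to 200000 nM, with a substantial chance that only a limit is reported.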

Compound 4, half-maximal inhibitory concentration: 9400 nM
For compound 4 the middle estimate is 11-fold (1.03 log units) above the measured one; the whole stated range lies above it.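

In this assay, hydrogen in place of methyl next to the ring oxygen now gives an at least 10-fold lower number from compound 2 to compound 4 (1.02 log units; beyond the scatter), a step beyond the scatter that the earlier pair did not show. The same change is therefore not flat on every core shown, although how far the two steps truly differ cannot be settled: the same change on two cores in this assay, an at least 1.0-fold lower number (0.02 log units; that floor lies within the scatter) from compound 1 to compound 3 and an at least 10-fold lower number (1.02 log units; beyond the scatter) from compound 2 to compound 4; the limit leaves it open whether they differ Because both methyl compounds rest on a limit, the full size of each step also stays unread: the limit of > 100000 nM in this assay, at which 2 of the 4 values shown sit.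

The compounds shown leave open whether hydrogen is the best group at this position, or whether an ethyl chain, a hydroxyl or an amine there would give a lower number still. They also leave open what would follow if the methyl group ortho to this position, present in all four compounds, gave way to hydrogen.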